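The source may report more compounds than this note shows. Statements on the series, on what has been measured and on what is new or still open speak of the compounds shown alone.

Compound 1 `Oc1cccc(CNc2cc(Br)cc3[nH]ncc23)c1`: 45%
Compound 2 `CCOC(=O)Nc1cccc(CNc2cc(Br)cc3[nH]ncc23)c1`: 29%

In an assay for inhibition of Indoleamine 2,3-dioxygenase 1 (Homo sapiens), with a stated time of 1 h, tested at 10 uM (a lower number here means less inhibition, a higher number more inhibition at the concentration tested (going by the name of the read-out)), compound 1 gives 45% and compound 2 gives 29%. Compound 2 stands at the lower of the two measured numbers. Going by the values given here, the only measured step is a number 16 percentage points lower from compound 1 to compound 2 (beyond the scatter).

Compound 3 `O=C(O)Nc1cccc(CNc2cc(Br)cc3[nH]ncc23)c1` differs from compound 2 by hydrogen in place of ethyl on an oxygen next to a carbonyl group. Among the compounds with values here, no measured step touches this oxygen, and the one measured step concerns a different change, so it gives no direction for this one. For compound 3 the expected step is a number 4 percentage points lower from compound 2 to compound 3 (within the scatter), within the scatter. In this assay compound 3 is estimated at 25%, with a range of 5% to 48%.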

Compound 3, a percentage reported as inhibition, at one concentration (the size of the read-out at that concentration, not a potency): 57%
The estimate for compound 3 lay 32 percentage points below the measured number; the whole stated range lies below it.
By their numbers in this assay, from the lowest: compound 2; then compound 1; then compound 3.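

In this assay, hydrogen in place of ethyl on an oxygen next to a carbonyl group gives a number 28 percentage points higher from compound 2 to compound 3 (beyond the scatter), so the outer end of this group strongly affects the read-out. Against hydroxy on the aromatic carbon, carboxyamino gives a number 12 percentage points higher from compound 1 to compound 3 (beyond the scatter), so groups at this place can fall on either side of hydroxy, and the ethyl decides the side. Nothing available explains this reversal. The compounds shown leave open whether a methyl or a longer chain on that oxygen would read closer to compound 2 or compound 3. They also leave open how an amine would compare at the aromatic carbon.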